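The compounds below may be only part of what the source reports. "The series", "measured", "known", "first", "only" and "open" are said of these compounds alone.

In a functional assay on A2780 cells (Homo sapiens) for antiproliferative activity, read by sulforhodamine B assay, with a stated time of 72 h (a higher number here means a weaker inhibitor, a lower number a stronger inhibitor), three compounds have been measured:
Compound 1 `O=C(NCc1ccc(S(=O)(=O)c2cc(F)cc(F)c2)cc1)c1cc2ccncc2o1` gives 9 nM
Compound 2 `O=C(NCc1ccc(S(=O)(=O)C2CCOCC2)cc1)c1cc2ccncc2o1` gives 87 nM
Compound 3 `O=C(NCc1ccc(S(=O)(=O)C2CCOCC2)cc1)c1cc2cnccc2[nH]1` gives 47 nM

Compound 2 stands level, within the scatter, with compound 3, and well away from compound 1, whose number is clearly lower. The next compound, compound 4 `Cc1ccc(S(=O)(=O)c2ccc(CNC(=O)c3cc4ccncc4o3)cc2)cn1`, keeps the core of compound 2 and changes only the group on the sulfonyl sulfur: 6-methylpyridin-3-yl in place of oxan-4-yl on a sulfonyl sulfur.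

The measured step that bears most directly on this is the one at the same place, a 9.7-fold higher number from compound 1 to compound 2 (0.99 log units; beyond the scatter), which lies beyond the scatter. Compound 4 runs in the opposite direction, with an aromatic ring returning to the sulfonyl sulfur. The other step, a 1.9-fold lower number from compound 2 to compound 3 (0.27 log units; within the scatter), concerns the group on the carbonyl carbon, which compound 4 leaves as it is in compound 2, and it offers little guidance here.

Among the measured compounds shown here, no compound with a 6-methylpyridin-3-yl group has been measured, and that group is not 3,5-difluorophenyl. Going by compound 1 at 9 nM, a lower number is expected in this assay, though probably not the full reversal. The estimated change is a 4.4-fold lower number from compound 2 to compound 4 (0.64 log units; beyond the scatter). The expected value for compound 4 is about 20 nM, with an estimated range from 6 nM to 60 nM.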

Compound 4, half-maximal inhibitory concentration: 5 nM
Beside the measured number, compound 4's estimate is 4.0-fold (0.60 log units) above it; the whole stated range lies above it.
By their numbers in this assay, from the lowest: compounds 4 and 1 (each within the scatter of the next); then compounds 3 and 2 (each within the scatter of the next).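

In this assay, placing 6-methylpyridin-3-yl on the sulfonyl sulfur in place of oxan-4-yl gives a 17-fold lower number from compound 2 to compound 4 (1.24 log units; beyond the scatter) and shows that the advantage earlier seen with 3,5-difluorophenyl at this position is not confined to that one aromatic group. The two aromatic groups stand level, with a 1.8-fold lower number from compound 1 to compound 4 (0.26 log units; within the scatter) within the scatter, so at this position the fluorine atoms of compound 1 are not required for a low number, and a ring holding a nitrogen serves equally well. Nothing measured in these data accounts for the gap between the aromatic groups and oxan-4-yl.

The compounds shown leave open whether a plain phenyl or an unsubstituted pyridin-3-yl on the sulfonyl sulfur would keep this level, which would separate the part played by the methyl group from that of the ring nitrogen. Also open, as far as these compounds go, are whether 6-methylpyridin-3-yl would hold its number with the carbonyl-bound group of compound 3, and whether a piperidin-4-yl amine would follow oxan-4-yl.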